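The source may hold more compounds than are shown below. What is called first, only, known or untested is meant among the compounds shown, and "the series" means these compounds.

Of the compounds shown here, three that share one core have so far been measured in a functional assay on HeLa cells (Homo sapiens) for cytotoxicity, read by MTT assay, with a stated time of 48 h; a higher number here means a weaker inhibitor, a lower number a stronger inhibitor. Compound 1 `Cc1ccc(Cn2cc(COc3ccc4c(=O)ccoc4c3)nn2)cc1` gives > 100000 nM in this assay; this is a limit of the assay, not a number. It sits at the limit of > 100000 nM in this assay, at which 1 of the 3 values shown sits, so no number is known for compound 1. Compound 2 `O=c1ccoc2cc(OCc3cn(Cc4ccc(Cl)cc4)nn3)ccc12` gives 37600 nM in this assay. Compound 3 `O=c1ccoc2cc(OCc3cn(Cc4cccc([N+](=O)[O-])c4)nn3)ccc12` gives 17300 nM in this assay. Of the two numbers, compound 2 stands highest, and the nearest is a 2.2-fold lower number from compound 2 to compound 3 (0.34 log units; beyond the scatter). The other steps read an at least 2.6-fold lower number from compound 1 to compound 2 (0.42 log units; beyond the scatter) and an at least 5.7-fold lower number from compound 1 to compound 3 (0.76 log units; beyond the scatter).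

Compound 4 `O=c1ccoc2cc(OCc3cn(Cc4ccc([N+](=O)[O-])cc4)nn3)ccc12` has not yet been measured. It differs from compound 2 in one place: nitro in place of chloro on an aromatic carbon. Within the data shown here, two measured steps bear on this change. The step of a 2.2-fold lower number from compound 2 to compound 3 (0.34 log units; beyond the scatter) also exchanged a chloro-bearing ring for a nitro-bearing one, 3-nitrophenyl in place of 4-chlorophenyl, and was modest in size. The step of an at least 2.6-fold lower number from compound 1 to compound 2 (0.42 log units; beyond the scatter) shows that a change of the group on this aromatic carbon alone can move the number beyond the scatter. A modest lowering is therefore expected in this assay, in the same direction as those two steps.

Compound 4 is expected to give about 20000 nM in this assay, in a range from 8000 nM to 50000 nM. That estimate means an expected step of a 1.9-fold lower number from compound 2 to compound 4 (0.27 log units; within the scatter).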

Compound 4, half-maximal inhibitory concentration: 25700 nM
Beside the measured number, compound 4's estimate is 1.3-fold (0.11 log units) below it; measured number inside the range.
By their numbers in this assay, from the lowest: compounds 3, 4 and 2 (each within the scatter of the next, the first and the last beyond it). At a limit, above all of these: compound 1.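

In this assay nitro in place of chloro on an aromatic carbon para to a large group gives a 1.5-fold lower number from compound 2 to compound 4 (0.17 log units; within the scatter), and moving the nitro group gives a 1.5-fold higher number from compound 3 to compound 4 (0.17 log units; within the scatter); compound 4 therefore cannot be told apart from either compound 2 or compound 3, although those two are separated from each other beyond the scatter. Nitro in place of methyl gives an at least 3.8-fold lower number from compound 1 to compound 4 (0.59 log units; beyond the scatter), so among the groups on this aromatic carbon in the 4-substituted compounds, only the methyl of compound 1 is set apart from the others. Compound 1 stands at a limit and not at a number, so this step has a bound but no known size: the limit of > 100000 nM in this assay, at which 1 of the 4 values shown sits.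

The compounds shown leave open whether an amine, a carboxylic acid or a longer chain at this place would give a number clearly apart from those of compound 2 and compound 4. They also leave open whether a ring carrying no group at all would sit with compound 1 or with the others.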